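A few compounds are considered here, and "the series" means these few. Any claim that something is new, unique, unknown or untested is made for them only; others in the source may bear on it.

Compound 1 `Nc1cc(N)c2nc(-c3ccccc3)c(NCc3ccc(Cl)c(Cl)c3)nc2c1` and compound 2 `COc1ccc(CNc2nc3cc(N)cc(N)c3nc2-c2ccccc2)cc1OC` share a core and differ only in the group carried on the saturated chain carbon bound to the ring nitrogen. In a functional assay on UACC-62 cells (Homo sapiens) for inhibition, read by sulforhodamine B assay, with a stated time of 48 h (a higher number here means a weaker inhibitor of growth, a lower number a stronger inhibitor of growth), compound 1 gives 14100 nM. In the same run compound 2 gives 12900 nM. Among the measured compounds shown here, the one step between them, a 1.1-fold lower number from compound 1 to compound 2 (0.04 log units; within the scatter), is the only comparison available. Compound 2 thus holds the lower of the two numbers, but its gap to compound 1 is within the scatter, so nothing separates the two on this evidence.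

Compound 3 `COc1cc(CNc2nc3cc(N)cc(N)c3nc2-c2ccccc2)cc(OC)c1OC` continues from compound 2 by a single alteration: methoxy in place of hydrogen on an aromatic carbon. For the measured compounds named here, no measured pair reports what a third methoxy group on this ring does. Going by the values given here, the only step at hand, the exchange of the whole dichlorophenyl for the dimethoxyphenyl, moved the number by an amount inside the scatter, which is weak guidance at best. The reasonable expectation is therefore no shift beyond the scatter in this assay for compound 3, with a step estimated at a 1.1-fold lower number from compound 2 to compound 3 (0.03 log units; within the scatter). Compound 3 is expected to give about 12000 nM, plausibly between 5000 nM and 30000 nM.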

Compound 3, concentration for 50% growth inhibition: 8130 nM
Estimate against measurement, compound 3: 1.5-fold (0.17 log units) above, within the range that was stated.
By their numbers in this assay, from the lowest: compounds 3, 2 and 1 (each within the scatter of the next).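

In this assay, methoxy in place of hydrogen on an aromatic carbon, ortho to a methoxy group and meta to a large group, gives a 1.6-fold lower number from compound 2 to compound 3 (0.20 log units; within the scatter), so this position carries the added group with no shift that can be told from the scatter. The pair of compound 1 and compound 2 spoke only to an exchange of the substituents on the whole ring, whereas compound 3 gives a reading for one group added to a ring that already carries methoxy groups, and this single addition likewise leaves the reading within the scatter. No measurement is at hand that would account for this step, so the result stands as a bare observation.

The compounds shown carry only chloro and methoxy groups on this ring, which leaves open what an amine or a carboxylic acid on the same aromatic carbon would give in this assay. Also open, as far as these compounds go, is whether a longer chain on the oxygen in place of methoxy would move the number beyond the scatter, since a single step at this position cannot settle that.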